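Swapping Nitro for Methoxy on a Shared Core

This account rests on a few compounds, and the source may have more. Where it says the series, first, only, none or still open, it means among the compounds named here.

Small changes to a molecule do not always shift how it divides between an oily and a watery phase, and this pair of measured compounds shows one such case. Compound 1 `OC[C@H]1O[C@H](Oc2ccc(-n3ccc4ccccc43)cc2Cl)[C@@H](O)[C@@H](O)[C@@H]1O` gives 1.8 in a physicochemical assay for lipophilicity, using the shake flask method, in phosphate buffer, measured as octanol-water partition, with a stated time of 2 h, at pH 7.4, tested at 1 uM; a higher number here means a more lipophilic compound, a lower number a more polar compound. Compound 2 `O=[N+]([O-])c1ccc2c(ccn2-c2ccc(O[C@H]3O[C@H](CO)[C@@H](O)[C@H](O)[C@@H]3O)c(Cl)c2)c1` carries a nitro group in place of a hydrogen on an aromatic carbon of the same core, and in this assay compound 2 gives 1.8, which places it level with compound 1.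

The next structure, compound 3 `COc1ccc2c(ccn2-c2ccc(O[C@H]3O[C@H](CO)[C@@H](O)[C@H](O)[C@@H]3O)c(Cl)c2)c1`, has methoxy in place of nitro on an aromatic carbon. For the measured compounds named here, only one measured step bears on this carbon, and adding the nitro group there gave no change at the digits printed from compound 1 to compound 2 (within the scatter). Going by the values given here, no measurement yet shows what methoxy does at this carbon, so this single step is slim evidence. On that basis, no shift beyond the scatter is expected, and no direction can be favoured. The estimated change is a number 0.10 log units higher from compound 2 to compound 3 (within the scatter). In this assay, the expected value for compound 3 is 1.9, with an estimated range of 1.5 to 2.3.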

Compound 3, distribution coefficient: 3
For compound 3 the middle estimate is 1.10 log units below the measured one, outside the stated range (above it).
By their numbers in this assay, from the lowest: compounds 1 and 2 (each within the scatter of the next); then compound 3.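

For the compounds shown here, this aromatic carbon looked unresponsive in this assay while nitro was the only group tried there, but the new compound changes that picture. Methoxy in place of nitro gives a number 1.20 log units higher from compound 2 to compound 3 (beyond the scatter) and methoxy in place of hydrogen gives a number 1.20 log units higher from compound 1 to compound 3 (beyond the scatter) on this same carbon, so the flat earlier step did not mean that whatever sits here leaves the reading unmoved: hydrogen and nitro stand level, while methoxy stands apart from both. Nothing measured here accounts for why methoxy differs from the other two, so this remains an observation about three compounds and not an explanation.

Going by these compounds, with only hydrogen, nitro and methoxy seen on this carbon, it remains open whether the jump is peculiar to methoxy or would also appear with a different group there, such as an amine, a carboxylic acid or a longer chain like ethoxy. The compounds shown also change only this one carbon, so they cannot tell whether methoxy placed on another carbon of the shared core would give a step of similar size.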